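Working notes: cytotoxicity readings and an estimate for compound 4

A few compounds are considered here, and "the series" means these few. Any claim that something is new, unique, unknown or untested is made for them only; others in the source may bear on it.

Three compounds have been measured in an ADME assay on PC-3 cells (Homo sapiens) for cytotoxicity, read by WST assay, tested at 100 uM; a higher number here means more inhibition at the concentration tested (going by the name of the read-out), a lower number less inhibition:

compound 1 `C=CCOc1cccc(NC(=O)C2CCCN(C(=O)c3cc(C(F)(F)F)cc(C(F)(F)F)c3)C2)c1` gives 0%
compound 2 `O=C(Nc1ccc(Cl)cc1)C1CCCN(C(=O)c2cccc([N+](=O)[O-])c2)C1` gives 0%
compound 3 `O=C(Nc1ccc(Cl)cc1)C1CCCN(C(=O)c2cccc(-c3cnco3)c2)C1` gives 0%

Compound 1 stands level with compounds 2 and 3 at the digits shown. Among the compounds with values here, the one step between measured compounds that differ in one place, no change at the digits printed from compound 2 to compound 3 (within the scatter), lies within the scatter, and it concerns a different part of the shared core than the change now considered.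

Compound 4 `CSc1cccc(NC(=O)C2CCCN(C(=O)c3cc(C(F)(F)F)cc(C(F)(F)F)c3)C2)c1` differs from compound 1 as follows: methylsulfanyl in place of allyloxy on an aromatic carbon. Within the data shown here, no measured step bears on this change, so nothing in the readings points to a move in either direction. The step from compound 1 to compound 4 is therefore expected to stay within the scatter, a number 2 percentage points higher from compound 1 to compound 4 (within the scatter). For compound 4 the estimate in this assay is 2%, with a range of -8% to 15%.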

Compound 4, a percentage reported as inhibition, at one concentration (the size of the read-out at that concentration, not a potency): 0%
Estimate against measurement, compound 4: 2 percentage points above, and the stated range covers the measured number.
By their numbers in this assay, from the lowest: compounds 1, 2, 3 and 4 (each within the scatter of the next).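

In this assay, within the data shown here, methylsulfanyl in place of allyloxy on an aromatic carbon, meta to a large group, gives no change at the digits printed from compound 1 to compound 4 (within the scatter), so this position now has a measured step that the earlier compounds did not supply. Losing the double bond of the allyloxy chain and exchanging its oxygen for sulfur therefore leaves the reading unmoved. No measurement at hand speaks to the reason for this.

From the compounds shown here alone, whether an amine or a carboxylic acid at this position would shift the reading remains open. So does the outcome with a longer chain there.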